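This account rests on a few compounds, and the source may have more. Where it says the series, first, only, none or still open, it means among the compounds named here.

Compound 1 `CC(C)(C)c1ccc(Oc2ccc3c(NCCCNCc4ccco4)ccnc3c2)cc1` gives 317 10^-6 cm/s in an ADME assay for permeability, using PAMPA, with a stated time of 30 min, at pH 7.4; a higher number here means that the compound crosses the layer faster, a lower number that the compound crosses the layer more slowly. Compound 2 `CC(C)(C)c1ccc(-c2ccc3c(NCCCNCc4ccco4)ccnc3c2)cc1` gives 237 10^-6 cm/s in this assay, and compound 3 `c1ccc(Cc2ccc3c(NCCCNCc4ccco4)ccnc3c2)cc1` gives 23 10^-6 cm/s, the lowest of the three numbers. Among the compounds with values here, the only step between measured compounds that differ in one place is a 10-fold lower number from compound 2 to compound 3 (1.01 log units; beyond the scatter). Compound 4 `COc1ccccc1Oc1ccc2c(NCCCNCc3ccco3)ccnc2c1` differs from compound 3 by 2-methoxyphenoxy in place of benzyl on an aromatic carbon. Within the data shown here, no measured step covers this exact change; the step from compound 2 to compound 3 shows how large a change at this aromatic carbon can be, and the values of compound 1 and compound 3 place the phenoxy-type group of compound 1 far above the benzyl of compound 3. For compound 4 the step of a 6.5-fold higher number from compound 3 to compound 4 (0.81 log units; beyond the scatter) is therefore expected, upward. Compound 4 is estimated at 150 10^-6 cm/s, within 50 10^-6 cm/s to 400 10^-6 cm/s.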

Compound 4, apparent permeability in the ADME assay: 317 10^-6 cm/s
Compound 4: middle estimate off by 2.1-fold (0.32 log units), on the low side; the measured number falls inside the stated range.
By their numbers in the ADME assay, from the lowest: compound 3; then compounds 2, 1 and 4 (each within the scatter of the next).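

In the ADME assay, 2-methoxyphenoxy in place of benzyl gives a 14-fold higher number from compound 3 to compound 4 (1.14 log units; beyond the scatter), so a high number at this aromatic carbon does not depend on the 4-(tert-butyl)phenyl group, as a 1.3-fold higher number from compound 2 to compound 4 (0.13 log units; within the scatter) and no change at the digits printed from compound 1 to compound 4 (within the scatter) also show. The same exchange also moves the number in a physicochemical assay for solubility, with a stated time of 18 h, at pH 7.4; a lower number here means a less soluble compound, a higher number a more soluble compound: the measured solubility of compound 3, 4200 nM, and of compound 4, 14500 nM, a 3.5-fold higher number (0.54 log units; beyond the scatter). In the physicochemical assay compound 3 gives 4200 nM and compound 4 gives 14500 nM. The compounds shown leave open whether the methoxy group or the oxygen link carries the step from benzyl, and what an amine or a carboxylic acid in place of the methoxy group would give in either assay.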